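Cytotoxicity notes on a diaryl sulfone amidoxime series

This account rests on a few compounds, and the source may have more. Where it says the series, first, only, none or still open, it means among the compounds named here.

In an ADME assay on THP-1 cells (Homo sapiens) for cytotoxicity, read by flow cytometry, with a stated time of 72 h (on this read-out lower numbers stand for stronger inhibition and higher numbers for weaker inhibition), compound 2 `CC1(Cc2ccccc2)CC(S(=O)(=O)c2ccc(Nc3cccc(/C(N)=N/O)c3)cc2)=C(c2ccc(/C(N)=N/O)cc2)O1` gives 46600 nM. Compound 1 `N/C(=N\O)c1ccc(Nc2ccc(C3=C(S(=O)(=O)c4ccc(/C(N)=N/O)cc4)CC(c4ccccc4)(c4ccccc4)O3)cc2)cc1` gives 48900 nM in this assay; the two numbers lie within the scatter of each other, so no order between them is read. Among the compounds with values here, no step between measured compounds is available. Compound 3 `CC1(Cc2ccccc2)CC(S(=O)(=O)c2ccc(/C=C/c3ccc(/C(N)=N/O)cc3)cc2)=C(c2ccc(/C(N)=N/O)cc2)O1` carries a group of 12 heavy atoms (9 carbon, 2 nitrogen, 1 oxygen; one six-membered aromatic ring of carbon only) in place of a group of 11 heavy atoms (7 carbon, 3 nitrogen, 1 oxygen; one six-membered aromatic ring of carbon only), on an aromatic carbon. Within the data shown here, nothing among the measured pairs tells what this change does here, so for compound 3 no step beyond the scatter is expected, and the estimate from compound 2 is a 1.2-fold lower number from compound 2 to compound 3 (0.07 log units; within the scatter). Compound 3 is expected at 40000 nM, within 15000 nM to 100000 nM.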

Compound 3, half-maximal inhibitory concentration: > 50000 nM
Compound 3 ended at the assay's limit; the forecaster's own chance of this, stated with the estimate: 15%; at least 1.2-fold (0.09 log units) between middle value and limit.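

At the aromatic carbon para to a large group, the group of 12 heavy atoms in place of the group of 11 heavy atoms gives an at least 1.0-fold higher number from compound 2 to compound 3 (0.03 log units; that floor lies within the scatter), the first step read at this position. In this assay compound 3 gives > 50000 nM, which is a limit and not a number. No lower number appears with this change, and the size of the step beyond its floor stays unread: the limit of > 50000 nM in this assay, at which 1 of the 3 values shown sits.

Open, as far as these compounds go, is whether an amine or a carboxylic acid on this aromatic carbon would give a number inside the range of this assay. Also open, from the compounds shown here alone, is whether any group here moves the read-out beyond the scatter.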